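Swapping chloro for amino on a shared core

The compounds below may be only part of what the source reports. "The series", "measured", "known", "first", "only" and "open" are said of these compounds alone.

Compound 1, with structure `Nc1nn(C(=O)Nc2ccc(Cc3ccccc3)cc2)c2ccccc12`, and compound 2, with structure `Nc1nn(C(=O)Nc2ccc(Cc3ccccc3)cc2)c2ccc(Cl)cc12`, differ only by chloro in place of hydrogen on an aromatic carbon. In a functional assay on M14 cells (Homo sapiens) for antiproliferative activity, read by sulforhodamine B assay, with a stated time of 48 h (on this read-out lower numbers stand for higher toxicity in this test and higher numbers for lower toxicity in this test), compound 1 gives > 100000 nM, which is a limit of the test rather than a number. In this assay compound 2 likewise gives > 100000 nM, again a limit and not a number. The step that the two limits leave unreadable from compound 1 to compound 2 therefore cannot be read in size, because of the limit of > 100000 nM in this assay, at which 2 of the 2 values shown sit. Compound 3, with structure `Nc1ccc2c(c1)c(N)nn2C(=O)Nc1ccc(Cc2ccccc2)cc1`, is not yet measured; it differs from compound 2 by amino in place of chloro on an aromatic carbon. Within the data shown here, only that one measured step bears on this change, and its size is not readable, so no direction beyond the scatter can be expected. Compound 3 is expected to give about 100000 nM in this assay, within a range from 30000 nM to 300000 nM. The step of a number no higher from compound 2 to compound 3 (the limit leaves the size open) so expected is essentially none.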

Compound 3, concentration lethal to 50% of the cells: 51900 nM
For compound 3 the middle estimate is 1.9-fold (0.28 log units) above the measured one, within the range that was stated.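

Among these compounds, compound 3 is the first compound here to give a number in this assay rather than a limit, so this position on the shared core can now be tied to a measured value. Amino in place of chloro gives an at least 1.9-fold lower number from compound 2 to compound 3 (0.28 log units; that floor lies within the scatter) and amino in place of hydrogen gives an at least 1.9-fold lower number from compound 1 to compound 3 (0.28 log units; that floor lies within the scatter) in the same test. Among the compounds shown here, each step is only a floor that lies within the scatter, so neither one by itself establishes a real change, though amino is the only group at this position with a measured number.

On these data alone, whether a hydroxyl, a methoxy or a carboxylic acid at this position would also give a number in this assay stays open. The true size of both steps also stays open, because compound 1 and compound 2 give only limits: the limit of > 100000 nM in this assay, at which 2 of the 3 values shown sit.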